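This account rests on a few compounds, and the source may have more. Where it says the series, first, only, none or still open, it means among the compounds named here.

Measured so far:
- compound 1 `CN(C)CCCCCn1c2c(c3ccccc31)C(=O)c1c[n+]([O-])c3ccccc3c1C2=O`: 370 nM
- compound 2 `O=C1c2c[n+]([O-])c3ccccc3c2C(=O)c2c1c1ccccc1n2Cc1cn(C[C@H](O)CO)nn1`: > 1000 nM (a limit, not a number)
- compound 3 `O=C1c2c[n+]([O-])c3ccccc3c2C(=O)c2c1c1ccccc1n2CCN1CCCCC1`: 1860 nM

All three results come from a functional assay on SH-SY5Y cells (Homo sapiens) for cytotoxicity, read by MTT assay, with a stated time of 72 h; a lower number here means a stronger inhibitor, a higher number a weaker inhibitor. Of the two true numbers, compound 3 has the higher, at 1860 nM, and the gap to the other is a 5.0-fold higher number from compound 1 to compound 3 (0.70 log units; beyond the scatter). Against the limit of compound 2 there is a step that the limit leaves unreadable from compound 2 to compound 3.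

The unmeasured compound 4 `O=C1c2c[n+]([O-])c3ccccc3c2C(=O)c2[nH]c3ccccc3c21` differs from compound 3 by hydrogen in place of 2-(piperidin-1-yl)ethyl on an aromatic nitrogen. In words, it has hydrogen in place of 2-(piperidin-1-yl)ethyl on an aromatic nitrogen.

Two measured steps alter the chain carried by that nitrogen: a 5.0-fold higher number from compound 1 to compound 3 (0.70 log units; beyond the scatter), and an at least 2.7-fold higher number from compound 1 to compound 2 (0.43 log units; beyond the scatter). Neither removes the chain altogether, so they offer a rough scale for compound 4 but no sure direction. Judged from compound 1 and its step of a 5.0-fold higher number from compound 1 to compound 3 (0.70 log units; beyond the scatter), the change in this assay is expected to be modest at most, and it may well stay within the scatter, with a slightly lower number only a weak guess. The expected change is a 1.6-fold lower number from compound 3 to compound 4 (0.19 log units; within the scatter). The estimated value for compound 4 is 1200 nM, with an expected range of 300 nM to 5000 nM.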

Compound 4, half-maximal inhibitory concentration: 1380 nM
The estimate for compound 4 lay 1.2-fold (0.06 log units) below the measured number, and the stated range covers the measured number.
By their numbers in this assay, from the lowest: compound 1; then compounds 4 and 3 (each within the scatter of the next).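

Among the compounds shown here, compound 4 shows for the first time what happens on this aromatic nitrogen with no chain at all. In this assay, hydrogen in place of 2-(piperidin-1-yl)ethyl gives a 1.3-fold lower number from compound 3 to compound 4 (0.13 log units; within the scatter), so this chain and bare hydrogen cannot be told apart, while hydrogen in place of 5-(dimethylamino)pentyl gives a 3.7-fold higher number from compound 1 to compound 4 (0.57 log units; beyond the scatter), so that chain alone, among the two with readable steps, stands apart from the chain-free compound, with the lower number on the side of compound 1. Compound 2 carries only a limit, and its step to compound 4 cannot be read: the limit of > 1000 nM in this assay, at which 1 of the 4 values shown sits.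

As far as these compounds go, whether the separation of compound 1 follows from the length of its chain or from its dimethylamino end stays open, and a 2-(dimethylamino)ethyl chain or a 5-(piperidin-1-yl)pentyl chain on this nitrogen would pull the two apart. How a small group such as methyl, or a chain ending in morpholine, would compare with hydrogen at this nitrogen also remains unknown from the compounds shown.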